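Chloro Replaces Hydrogen on Compound 2: What to Expect

The source may hold more compounds than are shown below. What is called first, only, known or untested is meant among the compounds shown, and "the series" means these compounds.

Of the compounds shown here, two have been measured in a functional assay on PC-12 cells (Rattus norvegicus) for cytotoxicity, read by MTT assay, with stated times of 3 h and 2 h, tested at 50 uM; a higher number here means a stronger effect of the compound at the concentration tested, a lower number a weaker effect. Compound 1 `COc1ccc(-c2cc3ccc(OCCCn4cc(CNC(=O)CCCCC5CCSS5)nn4)cc3oc2=O)cc1` gives 65.7% in this assay. Compound 2 `O=C(CCCCC1CCSS1)NCc1cn(CCCCOc2ccc3cc(-c4ccccc4)c(=O)oc3c2)nn1` gives 20.5%, the lower of the two numbers, standing well beneath compound 1. Compound 3 `O=C(CCCCC1CCSS1)NCc1cn(CCCCOc2ccc3cc(-c4ccc(Cl)cc4)c(=O)oc3c2)nn1` differs from compound 2 by chloro in place of hydrogen on an aromatic carbon. For the measured compounds named here, no measured pair differs in just one place, so nothing shows directly how a change of this kind moves the read-out in this assay. Compound 3 is therefore expected to stay near compound 2, with a step of a number 4.5 percentage points higher from compound 2 to compound 3 (within the scatter) expected to be none beyond the scatter. The activity of compound 3 is estimated at 25%, within 10% to 45%.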

Compound 3, a percentage reported as activity, at one concentration (the size of the read-out at that concentration, not a potency): 74.9%
Beside the measured number, compound 3's estimate is 49.9 percentage points below it; the measured number lies above the stated range.
By their numbers in this assay, from the lowest: compound 2; then compounds 1 and 3 (each within the scatter of the next).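

Replacing hydrogen with chloro on this six-membered aromatic ring, para to a large group, has a large effect in this assay, with a number 54.4 percentage points higher from compound 2 to compound 3 (beyond the scatter) for the change from phenyl to 4-chlorophenyl. For the compounds shown here, this is the first one-place comparison here, and it shows that a single chlorine atom at this position can move the read-out well beyond the scatter. Nothing available explains a step of this size.
Still open, going by these compounds, is whether this effect is specific to chloro, or whether fluoro, an amine or a carboxylic acid at the same place would move the read-out similarly.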